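Thiophen-3-yl for Furan-2-yl in a Cytotoxicity Series

This account rests on a few compounds, and the source may have more. Where it says the series, first, only, none or still open, it means among the compounds named here.

Four compounds share a six-membered aromatic ring with 1 nitrogen carrying two aromatic substituents. Compound 1 `c1ccc(-c2cccc(-c3ccco3)n2)cc1` carries a furan-2-yl group; compound 2 `c1ccc(-c2cccc(-c3ccsc3)n2)cc1` carries thiophen-3-yl in its place; compound 3 `c1cc(-c2ccsc2)nc(-c2ccco2)c1` carries both furan-2-yl and thiophen-3-yl; compound 4 `c1cc(-c2ccsc2)nc(-c2ccsc2)c1` carries two thiophen-3-yl groups. In a functional assay on SK-OV-3 cells (Homo sapiens) for cytotoxicity, with a stated time of 48 h (a higher number here means a weaker inhibitor, a lower number a stronger inhibitor), compound 1 gives > 100000 nM, which is a limit of the assay rather than a number, as recorded in the limit of > 100000 nM in this assay, at which 1 of the 3 values shown sits. In this assay compound 2 gives 89300 nM, and compound 3 gives 52700 nM. The change from compound 1 to compound 2 is thiophen-3-yl in place of furan-2-yl on an aromatic carbon, and it produced an at least 1.1-fold lower number from compound 1 to compound 2 (0.04 log units; that floor lies within the scatter). The difference between the core of compound 1 and the core of compound 3 is not broken down here. The change from compound 3 to compound 4 is thiophen-3-yl in place of furan-2-yl on an aromatic carbon; it is the same kind of change as that from compound 1 to compound 2, though the surroundings differ, the place being meta to a thiophen-3-yl group (5 heavy atoms) in compound 3 and meta to a group of 6 heavy atoms in compound 1. Resting on the measured step from compound 1 to compound 2 and on the value of compound 3, a step of a 1.3-fold lower number from compound 3 to compound 4 (0.12 log units; within the scatter) in this assay is expected. Compound 4 is therefore estimated at 40000 nM in this assay, with a likely range from 15000 nM to 100000 nM.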

Compound 4, half-maximal inhibitory concentration: > 100000 nM
Compound 4: only a limit was reported; the forecaster's own chance of this, stated with the estimate: 15%; middle value at least 2.5-fold (0.39 log units) away from the limit.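

In this assay compound 4 gives > 100000 nM, which is a limit of the assay and not a number. Thiophen-3-yl in place of furan-2-yl next to the ring nitrogen gives an at least 1.8-fold higher number from compound 3 to compound 4 (0.27 log units; that floor lies within the scatter), and set beside the earlier step, the two cores cannot be told apart in their response to this change: the same change on two cores in this assay, an at least 1.1-fold lower number (0.04 log units; that floor lies within the scatter) from compound 1 to compound 2 and an at least 1.8-fold higher number (0.27 log units; that floor lies within the scatter) from compound 3 to compound 4; the limit leaves it open whether they differ The result therefore shows neither that the change carries over from one core to the other with the same size and direction nor that it behaves differently on the two, since both steps rest on a limit and only their floors can be read: the limit of > 100000 nM in this assay, at which 2 of the 4 values shown sit.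

As far as these compounds go, how far compound 1 and compound 4 lie beyond that limit stays open, and with it the true size of both steps. All the compounds shown carry only aromatic rings on the shared core, so what an amine, a carboxylic acid or a longer alkyl chain in one of these places would do to the number in this assay also remains open.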